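A few compounds are considered here, and "the series" means these few. Any claim that something is new, unique, unknown or untested is made for them only; others in the source may bear on it.

Measured in a functional assay on BXPC-3 cells (Homo sapiens) for inhibition, read by MTT assay, with a stated time of 72 h; on this read-out lower numbers stand for stronger inhibition and higher numbers for weaker inhibition:
Compound 1 `O=C(Nc1cc(Cl)cc2cccnc12)c1ncccn1`: > 10000 nM
Compound 2 `NCCOc1cc(NC(=O)c2cnccn2)c2ncccc2c1`: > 10000 nM

Compound 2 gives > 10000 nM in this assay, which is a limit of the assay and not a number. It therefore offers no exact position, only a place at the assay's limit, shared by both measured compounds: the limit of > 10000 nM in this assay, at which 2 of the 2 values shown sit.

The next compound, compound 3 `NCCOc1cc(NC(=O)c2ncccn2)c2ncccc2c1`, has the same atoms as compound 2, joined differently. It carries pyrimidin-2-yl in place of pyrazin-2-yl on a carbonyl carbon.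

Among the measured compounds shown here, no measured step between two compounds is available to size this change. Compound 1 also carries pyrimidin-2-yl on a carbonyl carbon and gives > 10000 nM, again a limit of the assay. On that basis, the step expected in this assay is a step that the limit leaves unreadable from compound 2 to compound 3, estimated to stay within the scatter, with neither direction favoured. A reported limit is the likeliest outcome. The estimated value for compound 3 is 12000 nM, with an expected range from 5000 nM to 30000 nM.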

Compound 3, half-maximal inhibitory concentration: > 10000 nM
Compound 3 was reported as a limit (the forecaster's own chance of this, stated with the estimate: 80%); the middle value is on the limit's open side.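

In this assay compound 3 gives > 10000 nM, a limit of the assay and not a number. Among the compounds shown here, no step from compound 1 or compound 2 to compound 3 can be read, and the evidence is a single shared position: the limit of > 10000 nM in this assay, at which 3 of the 3 values shown sit. The compounds shown leave open whether exchanging pyrazin-2-yl for pyrimidin-2-yl, or chloro for 2-aminoethoxy, changes the result in this assay.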